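Cyclopropane substituent swap in a thioamidine series

The compounds below may be only part of what the source reports. "The series", "measured", "known", "first", "only" and "open" are said of these compounds alone.

Measured compounds:
- compound 1, `C[C@]1(c2cc(NC(=O)c3ccc(Cl)cn3)cc(F)c2F)N=C(N)S[C@H]2C[C@H]21`: 8.1
- compound 2, `C[C@]1(c2cc(NC(=O)c3ccc(Cl)cn3)cc(F)c2F)N=C(N)S[C@@]2(C(N)=O)C[C@H]21`: "not determined" (no result reported)

In a physicochemical assay for acid dissociation, read by spectrophotometry, at 25 degrees C, compound 1 gives 8.1. Among the compounds with values here, compound 2 carries a carbamoyl on a saturated ring carbon of the three-membered ring; in this assay compound 2 has no result, its entry reading "not determined" (no result reported), so there is no single number on which compound 2 stands and no step from compound 1 to compound 2 can be stated. The next compound is compound 3, `C[C@]1(c2cc(NC(=O)c3ccc(Cl)cn3)cc(F)c2F)N=C(N)S[C@@]2(C#N)C[C@H]21`, still to be measured in this assay.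

The change from compound 2 to compound 3 is cyano in place of carbamoyl on a saturated ring carbon

Within the data shown here, with no number for compound 2, the only anchor is compound 1 at 8.1. A step from compound 2 to compound 3 in this assay cannot be sized against a measured start point; against compound 1, a downward step of moderate size, beyond the usual scatter, is expected. On that basis compound 3 is estimated to give 7.3 in this assay, within a range of 6.6 to 8.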

Compound 3, acid dissociation constant: 6.2
The estimate for compound 3 lay 1.10 log units above the measured number, and the stated range ends above it.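

Within the data shown here, compound 2 has no single number in this assay, so no step to compound 3 at 6.2 can be read. The compounds shown leave open how swapping carbamoyl for cyano on the three-membered ring shifts this read-out. No supporting data bear on the result for compound 3.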